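The source may hold more compounds than are shown below. What is called first, only, known or untested is meant among the compounds shown, and "the series" means these compounds.

Working notes on the series. Compound 2 `Cc1c(C(=O)N/N=C\c2ccc(O)cc2)oc2cccc(O)c12` is one of two measured compounds; in a functional assay on PC-3 cells (Homo sapiens) for inhibition (on this read-out lower numbers stand for stronger inhibition and higher numbers for weaker inhibition), compound 2 gives 21700 nM, and compound 1 `Cc1c(C(=O)N/N=C\c2ccccc2C(F)(F)F)oc2cccc(O)c12` in this assay gives 26200 nM, the two values lying within the scatter of each other. Compound 3 `Cc1ccc(O)c(/C=N\NC(=O)c2oc3cccc(O)c3c2C)c1` has not yet been measured in this assay. It carries 2-hydroxy-5-methylphenyl in place of 4-hydroxyphenyl on a carbon with a double bond to nitrogen. Among the compounds with values here, no measured step of this kind exists, so no direction can be read from it; the expectation is a step from compound 2 to compound 3 of a 1.1-fold lower number from compound 2 to compound 3 (0.04 log units; within the scatter), not beyond the scatter. Compound 3 is thus estimated at 20000 nM, within 7000 nM to 60000 nM.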

Compound 3, half-maximal inhibitory concentration: 7350 nM
The estimate for compound 3 lay 2.7-fold (0.43 log units) above the measured number, and the stated range covers the measured number.
By their numbers in this assay, from the lowest: compound 3; then compounds 2 and 1 (each within the scatter of the next).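

At the carbon with a double bond to nitrogen, 2-hydroxy-5-methylphenyl in place of 4-hydroxyphenyl gives a 3.0-fold lower number from compound 2 to compound 3 (0.47 log units; beyond the scatter) in this assay. Within the data shown here, this is the first step to lie beyond the scatter, so the read-out does respond to a change at this place, though the step is modest. No measurement at hand bears on the origin of this step. From the compounds shown here alone, it remains open whether the hydroxyl or the methyl of the entering group carries the step, and how a phenyl group bearing an amine or a carboxylic acid would read at this place.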